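Adding a Methoxy Group to an Inactive Core

The source may report more compounds than this note shows. Statements on the series, on what has been measured and on what is new or still open speak of the compounds shown alone.

Of the compounds shown here, three sharing one core have been tested in a functional assay on HUVEC cells (Homo sapiens); a higher number here means that more compound is needed for the effect, a lower number that less compound is needed. Compound 1 `Cc1c(O)c(C)c2c(c1O)C(=O)CC(c1ccc(Cl)cc1)O2` gives only a limit, > 50000 nM. Compound 2 `Cc1c(O)c(C)c2c(c1O)C(=O)CC(c1ccc([N+](=O)[O-])cc1)O2` likewise gives only a limit, > 20000 nM. The step that the two limits leave unreadable from compound 1 to compound 2 therefore has no readable size. Compound 3 `COc1ccc(C2CC(=O)c3c(O)c(C)c(O)c(C)c3O2)cc1` is reported in this assay as "not active" (no number reported), without any number. The two other values shown are both limits: compound 1 sits at the limit of > 50000 nM in this assay, at which 1 of the 3 values shown sits, and compound 2 sits at the limit of > 20000 nM in this assay, at which 1 of the 3 values shown sits. Compound 3 thus stands among compounds for which no effect was reached. Compound 4 `COc1ccc(C2CC(=O)c3c(O)c(C)c(O)c(C)c3O2)c(OC)c1` differs from compound 3 by methoxy in place of hydrogen on an aromatic carbon. Among the measured compounds shown here, no measured step concerns this change, and the only measured step is unreadable and involves a different group. Compound 4 is therefore expected to behave much like compound 3 and to give about 50000 nM in this assay, within 10000 nM to 200000 nM, most likely reported again only as a limit.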

Compound 4, half-maximal effective concentration: "not active" (no number reported)
For compound 4 the study gives words and no number; there is nothing to compare the estimate with.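

Compound 3 and compound 4 are both reported only in words, as not active, so no step can be read between them. The compounds shown leave open whether any change on the shared core gives a measurable effect.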